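A few compounds are considered here, and "the series" means these few. Any claim that something is new, unique, unknown or untested is made for them only; others in the source may bear on it.

Measured compounds:
- compound 1, `CCN(CC)C1CCC(COCc2cc(C(F)(F)F)cc(C(F)(F)F)c2)(c2ccccc2)CC1`: 38 nM
- compound 2, `FC(F)(F)c1cc(COCC2(c3ccccc3)CCC(N3CCCCC3)C2)cc(C(F)(F)F)c1`: 4.7 nM
- compound 3, `FC(F)(F)c1cc(COCC2(c3ccccc3)CCC(NC3CC3)C2)cc(C(F)(F)F)c1`: 16 nM

In an assay on isolated protein for antagonist activity at Substance-P receptor (Homo sapiens) (a higher number here means a weaker inhibitor, a lower number a stronger inhibitor), compound 1 stands highest of the three numbers; compound 3 sits nearest to it and compound 2 furthest, both lower. Among the compounds with values here, no single-point step connects compound 1 to either of them.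

The unmeasured compound 4, `CN(C)C1CCC(COCc2cc(C(F)(F)F)cc(C(F)(F)F)c2)(c2ccccc2)CC1`, differs from compound 1 by dimethylamino in place of diethylamino on a saturated ring carbon. Within the data shown here, the only measured step that also changes the amine on a saturated ring carbon is a 3.4-fold higher number from compound 2 to compound 3 (0.53 log units; beyond the scatter), which exchanged a cyclic tertiary amine for a secondary one. The change from compound 1 to compound 4 is smaller in kind: both amines stay tertiary and acyclic, and only the two alkyl groups shrink. The step is therefore expected to be small, without a clear direction, and most likely within the scatter.

Compound 4 is expected to give 40 nM in this assay, within a range of 15 nM to 110 nM. The expected step of a 1.1-fold higher number from compound 1 to compound 4 (0.02 log units; within the scatter) would thus stay within the usual scatter.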

Compound 4, half-maximal inhibitory concentration: 48 nM
Beside the measured number, compound 4's estimate is 1.2-fold (0.08 log units) below it; measured number inside the range.
By their numbers in this assay, from the lowest: compound 2; then compound 3; then compounds 1 and 4 (each within the scatter of the next).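

In this assay, dimethylamino in place of diethylamino on the saturated ring carbon gives a 1.3-fold higher number from compound 1 to compound 4 (0.10 log units; within the scatter) and so leaves no readable change at this position. This is the only pair shown on the core of compound 1, and it keeps the amine tertiary and acyclic. The other amine step shown, on the core of compound 2, is a 3.4-fold higher number from compound 2 to compound 3 (0.53 log units; beyond the scatter) and exchanges piperidin-1-yl for cyclopropylamino. No measurement here bears on why compound 1 and compound 4 read alike.

Still open, going by these compounds, is how a primary amine or a pyrrolidin-1-yl group would read at this ring carbon on the core of compound 1. Also open, on these data alone, is whether piperidin-1-yl on that core would come near the value of compound 2 at 4.7 nM in this assay.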